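Swapping chloro for methyl on a formyl-bearing pyrazoline

The source may report more compounds than this note shows. Statements on the series, on what has been measured and on what is new or still open speak of the compounds shown alone.

Measured so far in a functional assay on the whole organism (strain Wistar) for inhibition, with Rattus norvegicus as the target, read by paw edema, with a stated time of 30 min, at a dose of 50 mg/kg by the oral route; a higher number here means more inhibition at the dose given (going by the name of the read-out), a lower number less inhibition:
- compound 1 `Cc1ccc(C2=NN(c3ccc([N+](=O)[O-])cc3)C(c3cn(-c4ccccc4)nc3-c3ccc(Cl)c(Cl)c3)C2)cc1` gives 57.4%
- compound 2 `O=CN1N=C(c2ccc(Cl)cc2)CC1c1cn(-c2ccccc2)nc1-c1ccc(Cl)c(Cl)c1` gives 35.1%

Among the measured compounds shown here, compound 2 stands lowest of the two numbers known in this assay; compound 1 sits above it by a gap that lies beyond the usual scatter. For the measured compounds named here, the two compounds differ in more than one place, so no single step between them can be drawn, and their values say only that compound 1 is the higher of the pair.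

Compound 3 `Cc1ccc(C2=NN(C=O)C(c3cn(-c4ccccc4)nc3-c3ccc(Cl)c(Cl)c3)C2)cc1` is not yet measured. It differs from compound 2 in one place: methyl in place of chloro on an aromatic carbon. Compound 1 also carries the methyl form of this ring, but its other differences keep it from serving as a direct guide.

Going by the values given here, with no comparable step to lean on, the change from compound 2 to compound 3 is expected to give a small rise, a number 5.9 percentage points higher from compound 2 to compound 3 (within the scatter), possibly staying within the scatter. Compound 3 is therefore expected to reach about 41% in this assay, within a range from 26% to 56%.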

Compound 3, a percentage reported as inhibition, in the whole organism at one dose (the size of the read-out at that dose, not a potency): 35.1%
Compound 3: the middle estimate sits 5.9 percentage points above what was measured; low and high end bracket the measured number.
By their numbers in this assay, from the lowest: compounds 2 and 3 (each within the scatter of the next); then compound 1.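

In this assay the change from 4-chlorophenyl to 4-methylphenyl gives no change at the digits printed from compound 2 to compound 3 (within the scatter) and so, at this one dose, chloro and methyl on this aromatic carbon cannot be told apart on the formyl-bearing core. Among the compounds shown here, compound 3 also provides the first comparison that differs in only one place on the ring nitrogen, where formyl in place of 4-nitrophenyl gives a number 22.3 percentage points lower from compound 1 to compound 3 (beyond the scatter) in the same assay, so the read-out shifts clearly with the change at that nitrogen but not with the change on the aromatic carbon. No measurement is available that could explain either result.

As far as these compounds go, it remains open whether an amine or a carboxylic acid in place of the methyl would move the read-out beyond the scatter, as two closely sized groups test only a narrow range of change at this position. From the compounds shown here alone, it is also open how much of the higher number depends on the nitro group of 4-nitrophenyl, a question that a plain phenyl or an acetyl on the ring nitrogen could begin to answer.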